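The compounds below may be only part of what the source reports. "The series", "measured", "known", "first", "only" and "open" are said of these compounds alone.

For the measured compounds named here, in an ADME assay on cells (Homo sapiens) for cytotoxicity, read by polymerase chain reaction, with a stated time of 3 days (a lower number here means that less compound is tolerated, a higher number that more compound is tolerated), compound 2, with the structure `Cc1nc(NCCOC(C)C)nc(N[C@@H]2C[C@H](CO)[C@@H](O)[C@H]2O)c1-c1nc2ccccc2s1`, gives 8000 nM; this is the only outright number among the two values recorded. Compound 1, with the structure `Cc1nc(NCC2CCC2)nc(N[C@@H]2C[C@H](CO)[C@@H](O)[C@H]2O)c1-c1nc2ccccc2s1`, gives > 25000 nM, which is a limit and not a number. Going by the values given here, the single measured step, an at least 3.1-fold lower number from compound 1 to compound 2 (0.49 log units; beyond the scatter), rests on (the limit of > 25000 nM in this assay, at which 1 of the 2 values shown sits), so its true size is not fully known. Compound 3, with the structure `Cc1nc(NCc2ccccc2)nc(N[C@@H]2C[C@H](CO)[C@@H](O)[C@H]2O)c1-c1nc2ccccc2s1`, has not yet been measured. It differs from compound 2 in one place: phenyl in place of isopropoxymethyl on a saturated chain carbon bound to a nitrogen on an aromatic ring. This is not the reverse of the measured step, but it again replaces a chain carrying one hydrogen-bond acceptor with a ring carrying none, and compound 1, which also carries a ring without an acceptor in that place, sits at the limit of > 25000 nM in this assay, at which 1 of the 2 values shown sits. The expected outcome is therefore a rise in the number, by a 1.9-fold higher number from compound 2 to compound 3 (0.27 log units; within the scatter), with a real chance that only a limit is reported. For compound 3 the estimated value is 15000 nM, within the range 5000 nM to 40000 nM.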

Compound 3, half-maximal cytotoxic concentration: 9000 nM
Compound 3: middle estimate off by 1.7-fold (0.22 log units), on the high side; the range from low to high includes it.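

In this assay, a 1.1-fold higher number from compound 2 to compound 3 (0.05 log units; within the scatter), so at this position isopropoxymethyl and phenyl cannot be told apart, although the first carries a hydrogen-bond acceptor and the second carries none; the absence of an acceptor on this group therefore does not by itself go with a number as high as that of compound 1. There is also an at least 2.7-fold lower number from compound 1 to compound 3 (0.44 log units; beyond the scatter), which shows that cyclobutyl stands apart from phenyl as well as from isopropoxymethyl, so the first step cannot be read simply as a ring giving way to a chain. Compound 1 gives > 25000 nM, which is a limit and not a number, and the true size of both steps from compound 1 stays unknown because of this: the limit of > 25000 nM in this assay, at which 1 of the 3 values shown sits.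

The compounds shown leave open whether the standing of cyclobutyl belongs to saturated rings more widely, which a cyclopentyl or cyclohexyl group on a saturated chain carbon bound to a nitrogen on an aromatic ring would test. They also leave open how an amine, a carboxylic acid or a longer chain in that place would read in this assay.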